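This account rests on a few compounds, and the source may have more. Where it says the series, first, only, none or still open, it means among the compounds named here.

Measured in a functional assay on HCT-116 cells (Homo sapiens) for antiproliferative activity, read by MTT assay, with a stated time of 72 h; a lower number here means a stronger inhibitor, a higher number a weaker inhibitor:
- Compound 1 `O=S1(=O)C=Cc2ccc(Nc3cccc(C(F)(F)F)c3)cc21`: 1370 nM
- Compound 2 `O=S1(=O)C=Cc2ccc(Nc3ccc(C(F)(F)F)cc3)cc21`: 1340 nM

Compound 1, at 1370 nM, stands level with compound 2, at 1340 nM, as the two numbers lie within the usual scatter of each other. Compound 3 `N#Cc1cccc(Nc2ccc3c(c2)S(=O)(=O)C=C3)c1` has not yet been measured. It carries cyano in place of trifluoromethyl on an aromatic carbon, meta to a large group: cyano in place of trifluoromethyl on an aromatic carbon. For the measured compounds named here, no measured pair shows this swap, so any forecast is uncertain. A modest rise in the number is expected in this assay, meaning somewhat weaker inhibition, and the estimated step is a 1.3-fold higher number from compound 1 to compound 3 (0.12 log units; within the scatter). Compound 3 is estimated at 1800 nM, with an expected range of 600 nM to 5500 nM.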

Compound 3, half-maximal inhibitory concentration: > 10000 nM
Compound 3: a limit, no number (the forecaster's own chance of this, stated with the estimate: 5%); at least 5.5-fold (0.74 log units) between middle value and limit.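

In this assay, this position does not tolerate every small group: cyano in place of trifluoromethyl gives an at least 7.2-fold higher number from compound 1 to compound 3 (0.86 log units; beyond the scatter). Compound 1 and compound 2 could not show this, since both carry trifluoromethyl. For compound 3 the value is a limit of the assay, not a number: the limit of > 10000 nM in this assay, at which 1 of the 3 values shown sits.

The compounds shown do not tell why this swap weakens inhibition so strongly. They also leave open whether an amine or a carboxylic acid at this position would keep the activity of compound 1.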